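Adding a Sulfonyl Group to Compound 3

This account rests on a few compounds, and the source may have more. Where it says the series, first, only, none or still open, it means among the compounds named here.

In a functional assay on U-937 cells (Homo sapiens) for cytotoxicity, read by MTT assay, with a stated time of 3 days (on this read-out higher numbers stand for weaker inhibition and lower numbers for stronger inhibition), compound 3 `N#Cc1c(-c2ccccc2)nc(SCc2nc3ccccc3[nH]2)nc1N1CCNCC1` gives 5.81 nM as the highest of three numbers. Compound 1 `CCNc1nc(SCc2nc3ccccc3[nH]2)nc(-c2ccccc2)c1C#N` gives 2.63 nM there and compound 2 `N#Cc1c(Nc2ccccn2)nc(SCc2nc3ccccc3[nH]2)nc1-c1ccccc1` gives 2.55 nM there. Compound 4 `N#Cc1c(-c2ccccc2)nc(SCc2nc3ccccc3[nH]2)nc1N1CCN(S(=O)(=O)c2ccccc2[N+](=O)[O-])CC1` differs from compound 3 by having (2-nitrophenyl)sulfonyl in place of hydrogen on an amine nitrogen in a ring, and the change counts as (2-nitrophenyl)sulfonyl in place of hydrogen on an amine nitrogen in a ring in all. Three measured steps offer some guidance. Replacing the group on the aromatic carbon gave a 2.2-fold higher number from compound 1 to compound 3 (0.34 log units; beyond the scatter) and a 2.3-fold higher number from compound 2 to compound 3 (0.36 log units; beyond the scatter) as modest moves, while pyridin-2-yl in place of ethyl gave a 1.0-fold lower number from compound 1 to compound 2 (0.01 log units; within the scatter) with no change beyond the scatter. From the compounds shown here alone, none of these steps adds a group to that amine nitrogen, so this large addition is untested here. Going by these compounds, with compound 3 at 5.81 nM and only such small steps to go on, no step beyond the scatter is expected in this assay and either direction remains open. The estimated change is a 1.2-fold lower number from compound 3 to compound 4 (0.07 log units; within the scatter) on this reasoning. Compound 4 is estimated at 5 nM with an expected range from 1.5 nM to 20 nM for a measurement.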

Compound 4, half-maximal inhibitory concentration: 3.28 nM
The estimate for compound 4 lay 1.5-fold (0.18 log units) above the measured number; the measured number falls inside the stated range.
By their numbers in this assay, from the lowest: compounds 2, 1, 4 and 3 (each within the scatter of the next, the first and the last beyond it).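

In this assay, putting (2-nitrophenyl)sulfonyl on the amine nitrogen in the ring gives a 1.8-fold lower number from compound 3 to compound 4 (0.25 log units; within the scatter) and so no shift beyond the scatter. Going by these compounds alone, the earlier steps changed only the group on the aromatic carbon, so this is the first view of that nitrogen: it can carry an addition of 12 heavy atoms, including an aromatic ring, while the number stays within the scatter of compound 3. No measurement at hand explains why so large an addition leaves the number within the scatter.

The compounds shown leave open whether the nitro group or the sulfonyl link matters, which a plain phenylsulfonyl or an acetyl on the same nitrogen could test. A small methyl or a longer alkyl chain there would show whether other kinds of group are accepted as well.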